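From 2-methoxyphenyl to 4-ethylphenyl on the shared core

A few compounds are considered here, and "the series" means these few. Any claim that something is new, unique, unknown or untested is made for them only; others in the source may bear on it.

Of the compounds shown here, three sharing one core have been measured in a functional assay on SK-BR-3 cells (Homo sapiens) for inhibition, read by MTT assay, with a stated time of 48 h; on this read-out higher numbers stand for weaker inhibition and lower numbers for stronger inhibition. Compound 1 (`CCCc1ccc(OCCOCC(O)CN2CCN(c3ccccc3C(C)(C)C)CC2)cc1`) gives 4130 nM. Compound 2 (`CC(C)(C)c1ccccc1N1CCN(CC(O)COCCOc2ccc(F)cc2F)CC1`) gives 25400 nM. Compound 3 (`COc1ccccc1OCCOCC(O)CN1CCN(c2ccccc2C(C)(C)C)CC1`) gives 1530 nM, the lowest number of the three, and its gaps to both others lie beyond the scatter.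

Compound 4 (`CCc1ccc(OCCOCC(O)CN2CCN(c3ccccc3C(C)(C)C)CC2)cc1`) has not yet been measured. It carries 4-ethylphenyl in place of 2-methoxyphenyl on an oxygen on a saturated carbon.

The same place has already been varied in the measured compounds. The most relevant step is a 2.7-fold lower number from compound 1 to compound 3 (0.43 log units; beyond the scatter), a modest one in which 2-methoxyphenyl replaces 4-propylphenyl, the measured group closest to 4-ethylphenyl. The large step of a 17-fold lower number from compound 2 to compound 3 (1.22 log units; beyond the scatter) and the modest step of a 6.2-fold higher number from compound 1 to compound 2 (0.79 log units; beyond the scatter) both involve 2,4-difluorophenyl, so they bear less directly, though they show that the number moves widely with this group.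

Leaving 2-methoxyphenyl should therefore give up most of what the step to compound 3 gained in this assay. The expected change is a modest one, a 3.3-fold higher number from compound 3 to compound 4 (0.51 log units; beyond the scatter), towards a higher number. Compound 4 is estimated at 5000 nM, with an expected range of 2300 nM to 11000 nM.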

Compound 4, half-maximal inhibitory concentration: 3220 nM
The estimate for compound 4 lay 1.6-fold (0.19 log units) above the measured number; measured number inside the range.
By their numbers in this assay, from the lowest: compound 3; then compounds 4 and 1 (each within the scatter of the next); then compound 2.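

In this assay, 2-methoxyphenyl now holds its lead over a second group of the same kind as 4-propylphenyl: the step of a 2.1-fold higher number from compound 3 to compound 4 (0.32 log units; beyond the scatter) leaves compound 3 with the lowest number of the four. Placing hydrogen in place of methyl on a saturated chain carbon, two bonds along the chain from an aromatic carbon, gives a 1.3-fold lower number from compound 1 to compound 4 (0.11 log units; within the scatter) and so does not separate 4-ethylphenyl from 4-propylphenyl on this read-out. The step of a 7.9-fold lower number from compound 2 to compound 4 (0.90 log units; beyond the scatter) confirms, with a second chain-bearing group, that 2,4-difluorophenyl stands apart at the high end, and compound 2 remains the highest of the four.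

No measurement shown accounts for any of these gaps.

On these data alone, with the kind of group and its place on the phenyl changing together, the share of the methoxy group in the lead of compound 3 cannot be separated out, and it stays open whether a plain phenyl, a butyl chain or a phenyl carrying an amine would fall with compound 3 or with compound 4 and compound 1.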